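The compounds below may be only part of what the source reports. "The series", "measured", "known", "first", "only" and "open" are said of these compounds alone.

Working notes on the series, read in an ADME assay on BHK-21 cells (Mesocricetus auratus) for cytotoxicity, read by MTT assay, with a stated time of 72 h; a higher number here means that more compound is tolerated, a lower number that less compound is tolerated. Compound 1 `Cc1ccccc1C1CC(c2ccc(OCc3ccccc3)cc2)=NN1c1ccc(S(N)(=O)=O)cc1` gives 20000 nM, compound 2 `NS(=O)(=O)c1ccc(N2N=C(c3ccc(Oc4ccccc4)cc3)CC2c2cccc(F)c2)cc1` gives 10000 nM, and compound 3 `NS(=O)(=O)c1ccc(N2N=C(c3ccc(OCc4ccccc4)cc3)CC2c2cccc(F)c2)cc1` gives 9000 nM. Compound 2 stands within the scatter of both compound 3 and compound 1, although a step beyond the scatter separates those two.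

Compound 4 `NS(=O)(=O)c1ccc(N2N=C(c3ccc(Oc4ccccc4)cc3)CC2c2ccc(Cl)cc2)cc1` keeps the rest of compound 2 and changes one group: 4-chlorophenyl in place of 3-fluorophenyl on a saturated ring carbon. In words, 4-chlorophenyl takes the place of 3-fluorophenyl on a saturated ring carbon.

The closest evidence is the change of group on that same carbon, a 2.2-fold lower number from compound 1 to compound 3 (0.35 log units; beyond the scatter), which is modest and swaps 2-methylphenyl for 3-fluorophenyl. The other measured change, benzyl in place of phenyl on an oxygen on an aromatic ring, is at a different place and gives a 1.1-fold lower number from compound 2 to compound 3 (0.05 log units; within the scatter), within the scatter. Going by the values given here, no measured compound carries a 4-chlorophenyl group, so the data give no direction for this change. With only a modest step seen at this carbon, from compound 1 to compound 3, no step beyond the scatter is expected in this assay.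

For compound 4 the expected value is 9000 nM, with an estimated range from 4500 nM to 18000 nM. The estimate corresponds to an expected 1.1-fold lower number from compound 2 to compound 4 (0.05 log units; within the scatter).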

Compound 4, half-maximal cytotoxic concentration: 7000 nM
Beside the measured number, compound 4's estimate is 1.3-fold (0.11 log units) above it; the range from low to high includes it.
By their numbers in this assay, from the lowest: compounds 4, 3, 2 and 1 (each within the scatter of the next, the first and the last beyond it).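

With 4-chlorophenyl in place of 3-fluorophenyl on the saturated ring carbon, this assay gives a 1.4-fold lower number from compound 2 to compound 4 (0.15 log units; within the scatter), a second step at this position that, unlike a 2.2-fold lower number from compound 1 to compound 3 (0.35 log units; beyond the scatter), does not leave the scatter. The 3-fluorophenyl and 4-chlorophenyl groups are therefore not told apart in this assay when the phenyl on the oxygen stays in place, so changing the group on this carbon does not always move the number beyond the scatter. No data at hand bear on what lies behind either step at this carbon.

On these data alone, all groups seen on this carbon so far are substituted phenyl rings, so it remains open how the number responds to an amine, a carboxylic acid or a longer chain there in place of the ring. As far as these compounds go, it also remains open whether the 4-chlorophenyl group gives a similar reading with benzyl in place of phenyl on the oxygen, or with a group other than the 4-sulfamoylphenyl group on the ring nitrogen.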